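The source may hold more compounds than are shown below. What is called first, only, known or untested is meant among the compounds shown, and "the series" means these compounds.

Working notes on the series.

Compound 1, `CCN1CCc2c(sc(NC(=O)Nc3ccc(Br)cc3)c2C(N)=O)C1`, is the weakest of the three measured compounds in a functional assay (strain AB) with Danio rerio as the target, read by microscopy, with a stated time of 1 h; a higher number here means that more compound is needed for the effect, a lower number that less compound is needed: compound 1 gives 3130 nM. Compound 2, `CC(C)(C)OC(=O)CCCCCN1CCc2c(sc(NC(=O)Nc3ccc(Cl)cc3)c2C(N)=O)C1`, gives 620 nM in this assay, a lower number than compound 1 by a margin beyond the scatter. Compound 3, `CC[N+]1(CC2CC2)CCc2c(sc(NC(=O)Nc3ccc(Cl)cc3)c2C(N)=O)C1`, gives 100 nM in this assay and stands furthest from compound 1, again beyond the scatter. Among the measured compounds shown here, no single-point step between any two of these measured compounds is available, so their values can only be set side by side; they share a common core and differ in more than one place at once.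

Compound 4, `CCN1CCc2c(sc(NC(=O)Nc3cccc(C#N)c3)c2C(N)=O)C1`, has not yet been measured in this assay. It differs from compound 1 in one place: 3-cyanophenyl in place of 4-bromophenyl on an amide-type nitrogen. For the measured compounds named here, no measured pair in the set changes this part of the molecule, so the size and direction of the step are not anchored by data. On balance a small step, if any, is expected, with a modest rise in the number as the more likely outcome; the step from a 1.6-fold higher number from compound 1 to compound 4 (0.20 log units; within the scatter) is estimated as lying near the edge of the scatter. Compound 4 is therefore expected to give about 5000 nM in this assay, within a range of 1500 nM to 16000 nM.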

Compound 4, half-maximal effective concentration: 10300 nM
The estimate for compound 4 lay 2.1-fold (0.31 log units) below the measured number; low and high end bracket the measured number.
By their numbers in this assay, from the lowest: compound 3; then compound 2; then compound 1; then compound 4.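

The group on the amide-type nitrogen is not indifferent in this assay: with the rest of the molecule held fixed, 3-cyanophenyl in place of 4-bromophenyl gives a 3.3-fold higher number from compound 1 to compound 4 (0.52 log units; beyond the scatter) and so raises the number. Among the compounds shown here, this is the first step that can be read at a single place, since the earlier compounds differed in more than one place at once and their values could only be set side by side. Nothing in hand accounts for the direction or size of this step.

The swap changes both the substituent and its place on the phenyl group, and the compounds shown do not separate the two; 4-cyanophenyl or 3-bromophenyl would be needed to tell them apart. Also open, as far as these compounds go, are how an unsubstituted phenyl or 4-methoxyphenyl would compare on this core, and whether a step of this size would carry over to the more elaborate groups on the ring nitrogen of compound 2 and compound 3, which both carry 4-chlorophenyl here.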